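The compounds below may be only part of what the source reports. "The series", "measured", "known", "first", "only" and "open" are said of these compounds alone.

The four compounds share one core, an aryloxyacetamide bearing a thiophen-2-ylmethyl group on the amide nitrogen, and differ mainly in the third substituent on that nitrogen. Compound 1 `Cc1ccc(OCC(=O)N(Cc2cccs2)c2ncco2)cc1` carries a 1,3-oxazol-2-yl there and in an assay on HEK293 cells for agonist activity at transient receptor potential cation channel subfamily M member 8 (Homo sapiens), read by fluorescence and calcium flux, with a stated time of 15 min (a higher number here means that more compound is needed for the effect, a lower number that less compound is needed), compound 1 gives 0.3 nM. Compound 2 `Cc1ccc(OCC(=O)N(Cc2cccs2)c2ccnn2C)cc1` carries a 1-methyl-1H-pyrazol-5-yl instead, and in this assay compound 2 gives 422 nM, the second highest of the three numbers. For the measured compounds named here, the single measured step, a 1400-fold higher number from compound 1 to compound 2 (3.15 log units; beyond the scatter), is large. Compound 3 `CCN(Cc1cccs1)C(=O)C(C)Oc1ccc(C)cc1` has an ethyl on the nitrogen and a methyl on the chain carbon, and in this assay compound 3 gives 889 nM, a number close to that of compound 2.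

Compound 4 `Cc1ccc(OCC(=O)N(C)Cc2cccs2)cc1` is the unmeasured member; the change from compound 2 is methyl in place of 1-methyl-1H-pyrazol-5-yl on an amide-type nitrogen. Going by the values given here, no measured step matches it exactly. Among the compounds with values here, the only nitrogen-substituent step known is a 1400-fold higher number from compound 1 to compound 2 (3.15 log units; beyond the scatter), which shows that this position can move the number strongly, and compound 3, the one compound with a small alkyl on the nitrogen, sits close to compound 2. For compound 4 a moderate rise is therefore expected, a 2.4-fold higher number from compound 2 to compound 4 (0.37 log units; beyond the scatter). Compound 4 is estimated at 1000 nM, with a range from 200 nM to 6000 nM.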

Compound 4, half-maximal effective concentration: 400 nM
Compound 4: middle estimate off by 2.5-fold (0.40 log units), on the high side; low and high end bracket the measured number.
By their numbers in this assay, from the lowest: compound 1; then compounds 4 and 2 (each within the scatter of the next); then compound 3.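

In this assay, the step on the amide-type nitrogen from the 1-methyl-1H-pyrazol-5-yl to methyl is a 1.1-fold lower number from compound 2 to compound 4 (0.02 log units; within the scatter) so a group of 6 heavy atoms with one five-membered aromatic ring and a group of a single carbon give numbers that cannot be told apart here. The other step at this position, a 1300-fold higher number from compound 1 to compound 4 (3.12 log units; beyond the scatter) shows that, of the three groups compared on this nitrogen, only the 1,3-oxazol-2-yl of compound 1 stands apart, and that the large gap seen earlier does not simply follow from the presence of a five-membered aromatic ring, as the ring of compound 2 and the methyl of compound 4 read alike. Nothing at hand accounts for the position of the 1,3-oxazol-2-yl.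

The compounds shown leave open how closely the low number is tied to the 1,3-oxazol-2-yl, since they do not tell how a 1,3-thiazol-2-yl, a pyridin-2-yl or a phenyl would read on this nitrogen. They also leave open whether a longer chain in place of methyl would read like compound 4, and whether the 1,3-oxazol-2-yl would keep its low number with another group in place of the thiophen-2-ylmethyl.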